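Two Methyls on the Pyridyl Ether: Expected Lipophilicity Rise

The source may report more compounds than this note shows. Statements on the series, on what has been measured and on what is new or still open speak of the compounds shown alone.

Of the compounds shown here, three share a core and have been measured in a physicochemical assay for lipophilicity, read by LC-MS, in phosphate buffer, measured as octanol-water partition, with a stated time of 30 min, at pH 7.4, tested at 200 mM; on this read-out lower numbers stand for lower lipophilicity and higher numbers for higher lipophilicity. Compound 1 `Cc1ccc(Oc2ccc3nc(COc4cccc(C(=O)O)c4)n(C)c3n2)cc1F` gives 2.1 in this assay. Compound 2 `Cn1c(COc2cccc(C(=O)O)c2)nc2cnc(Oc3ccc(Cl)c(F)c3)cc21` gives 1.4. Compound 3 `Cn1c(COc2cccc(C(=O)O)c2)nc2ccc(Oc3ccccn3)cc21` gives 0.4, the lowest of the three numbers; compound 2 lies above it beyond the scatter, and compound 1 lies further above it, also beyond the scatter. For the measured compounds named here, none of these three differ from each other in a single place, so no step between measured compounds can be drawn.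

Compound 4 `Cc1ccc(C)c(Oc2ccc3nc(COc4cccc(C(=O)O)c4)n(C)c3c2)n1` has not yet been measured in this assay. It differs from compound 3 in one place: 3,6-dimethylpyridin-2-yl in place of pyridin-2-yl on an oxygen on an aromatic ring. Going by the values given here, since the only change is two added methyl groups on the pyridin-2-yl, with the donor and acceptor count unchanged, the step is expected to be upward and of moderate size, beyond the scatter, as an estimate of a number 0.90 log units higher from compound 3 to compound 4 (beyond the scatter). Compound 4 is therefore estimated to give 1.3 in this assay, expected within a range from 0.8 to 1.8.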

Compound 4, distribution coefficient: 1.4
Beside the measured number, compound 4's estimate is 0.10 log units below it; measured number inside the range.
By their numbers in this assay, from the lowest: compound 3; then compounds 2 and 4 (each within the scatter of the next); then compound 1.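

For the compounds shown here, compound 3 and compound 4 give the first pair in this set that differs in one place, so the aryl group on the oxygen can now be read directly: in this assay the change from pyridin-2-yl to 3,6-dimethylpyridin-2-yl is a number 1.00 log units higher from compound 3 to compound 4 (beyond the scatter) and is the only step available so far. The exchange takes the group from 6 heavy atoms to 8 and leaves its hydrogen-bond donor and acceptor counts as they were, so this position shows a clear shift in the read-out with those counts held constant. Nothing at hand accounts for the size of this step.

As far as these compounds go, whether either methyl group alone would give part or all of the step remains open. So does how an ethyl group, a methoxy group or an amine on the same pyridine ring would read.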